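The source may hold more compounds than are shown below. What is called first, only, known or untested is meant among the compounds shown, and "the series" means these compounds.

Measured so far:
Compound 1, `COc1cc(C(=O)c2sc3ccccc3c2-c2ccc(C)cc2)cc(OC)c1OC`, gives 3700 nM in a functional assay on HeLa cells (Homo sapiens) for antiproliferative activity, read by MTT assay, with a stated time of 72 h; a higher number here means a weaker inhibitor, a lower number a stronger inhibitor.
Compound 2, `CCOc1ccc(-c2c(C(=O)c3cc(OC)c(OC)c(OC)c3)sc3ccccc23)cc1`, gives 3000 nM in this assay.
Compound 3, `COc1cc(C(=O)c2sc3cc(C)ccc3c2Nc2ccc(C)cc2)cc(OC)c1OC`, gives 980 nM in this assay.

Compound 1 and compound 2 differ in one place only: ethoxy in place of methyl on an aromatic carbon. That change gave a 1.2-fold lower number from compound 1 to compound 2 (0.09 log units; within the scatter), so the two numbers are not told apart by this assay. Compound 3 has a different core; the difference between its core and the core of compound 1 is not broken down here. Its number in this assay is lower than those of compound 1 and compound 2, and in both cases the gap is beyond the scatter.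

Compound 4, `CCOc1ccc(Nc2c(C(=O)c3cc(OC)c(OC)c(OC)c3)sc3cc(C)ccc23)cc1`, has not yet been measured. It differs from compound 3 by ethoxy in place of methyl on an aromatic carbon. The place of the change is described in the same words as for the step from compound 1 to compound 2, so it is the same change applied to the core of compound 3. Because a 1.2-fold lower number from compound 1 to compound 2 (0.09 log units; within the scatter) stayed within the scatter, the expected step here is a 1.2-fold lower number from compound 3 to compound 4 (0.06 log units; within the scatter), a small one. Compound 4 is therefore estimated at 850 nM, likely between 400 nM and 1800 nM.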

Compound 4, half-maximal inhibitory concentration: 4300 nM
For compound 4 the middle estimate is 5.1-fold (0.70 log units) below the measured one; measured number above the stated range.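

In this assay the new measurement gives a 4.4-fold higher number from compound 3 to compound 4 (0.64 log units; beyond the scatter), so on the core of compound 3, ethoxy in place of methyl on the aromatic ring goes with weaker activity. Set beside the earlier step, this shows that the result of the change on one core cannot simply be carried over to another core in this series: the same change on two cores in this assay, a 1.2-fold lower number (0.09 log units; within the scatter) from compound 1 to compound 2 and a 4.4-fold higher number (0.64 log units; beyond the scatter) from compound 3 to compound 4, 5.4-fold (0.73 log units) apart, beyond the scatter of two such steps. It does not show the reason for the mismatch, and two pairs of compounds cannot predict how the same change would behave on any further core.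

The compounds shown leave open how other groups in this position, such as an amine, a carboxylic acid or a longer chain like butoxy, would compare with methyl and ethoxy on either core. No pair shown changes only one part of the difference between the two cores, so it also stays open which part decides the size of the step.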